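The source may report more compounds than this note shows. Statements on the series, on what has been measured and on what is new or still open speak of the compounds shown alone.

Working notes on the series in an assay on HeLa cells for inhibition of sphingosine-1-phosphate transporter SPNS2 (Mus musculus), read by LC-MS, tested at 2 uM; a higher number here means more inhibition at the concentration tested (going by the name of the read-out), a lower number less inhibition:

compound 1, `CCCCCCCCCCc1ccc(-c2noc(CCCN(C)C)n2)cc1`, gives 8%
compound 2, `CCCCCCCCCCc1ccc(-c2noc(C3CCNC3)n2)cc1`, gives 26%
compound 3, `CCCCCCCCCCc1ccc(-c2noc(C(Cl)CCN)n2)cc1`, gives 5%

Compound 2 stands highest of the three numbers in this assay. Its nearest neighbour is compound 1, with a number 18 percentage points higher from compound 1 to compound 2 (beyond the scatter); its furthest is compound 3, with a number 21 percentage points lower from compound 2 to compound 3 (beyond the scatter). Between compound 1 and compound 3 the step is a number 3 percentage points lower from compound 1 to compound 3 (within the scatter), so those two are not separated.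

Compound 4, `CCCCCCCCCCc1ccc(-c2noc([C@@H](N)CCCCN)n2)cc1`, is not yet measured. Against compound 2 the change is 1,5-diaminopentyl in place of pyrrolidin-3-yl on an aromatic carbon. Going by the values given here, two measured steps bear on this change, as both also replace pyrrolidin-3-yl by a group with no ring on the same aromatic carbon: the reverse of a number 18 percentage points higher from compound 1 to compound 2 (beyond the scatter) and a number 21 percentage points lower from compound 2 to compound 3 (beyond the scatter). Both point the same way, a modest fall when pyrrolidin-3-yl leaves for a chain. Among the compounds with values here, the entering 1,5-diaminopentyl has no measured counterpart, so the size is uncertain, but the direction from these two steps is downward. Compound 4 is therefore expected to give 14%, in the range 3% to 32%, a step of a number 12 percentage points lower from compound 2 to compound 4 (beyond the scatter) expected in this assay.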

Compound 4, a percentage reported as inhibition, at one concentration (the size of the read-out at that concentration, not a potency): 43%
Compound 4: the middle estimate sits 29 percentage points below what was measured; the measured number lies above the stated range.
By their numbers in this assay, from the lowest: compounds 3 and 1 (each within the scatter of the next); then compound 2; then compound 4.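

In this assay, a group with no ring on this aromatic carbon can raise the number: there is a number 17 percentage points higher from compound 2 to compound 4 (beyond the scatter), so the loss of pyrrolidin-3-yl does not by itself bring a fall, and compound 1 and compound 3 do not speak for open chains in general. The open chains also differ widely among themselves, with a number 35 percentage points higher from compound 1 to compound 4 (beyond the scatter) and a number 38 percentage points higher from compound 3 to compound 4 (beyond the scatter), which places compound 4 highest of the four and shows that, among these compounds, the choice of chain can matter as much as the presence of a ring. Nothing at hand gives a reason for the rise.

Which feature of 1,5-diaminopentyl carries the gain stays open: compared with pyrrolidin-3-yl, it brings a different heavy-atom count, a second amine, no ring and a defined stereocentre all at once. A pentyl chain with a single amine, a longer chain with both amines, the mirror-image form of compound 4 or a carboxylic acid in place of one amine would each bear on this question.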